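The compounds below may be only part of what the source reports. "The series", "measured", "known", "first", "only" and "open" are said of these compounds alone.

Compound 1 `N=C(N)c1ccc2[nH]c(-c3ccc4nc(-c5ccc(F)c(F)c5)[nH]c4c3)nc2c1`: 29.8 ug/mL
Compound 2 `N=C(N)c1ccc2[nH]c(-c3ccc4nc(-c5ccccc5Oc5ccc(Cl)cc5)[nH]c4c3)nc2c1`: > 90 ug/mL
Compound 3 `N=C(N)c1ccc2[nH]c(-c3ccc4nc(-c5ccc(Oc6ccc(Cl)cc6)cc5)[nH]c4c3)nc2c1`: 46 ug/mL

All three compounds were tested in an ADME assay on L6 cells (Rattus norvegicus) for cytotoxicity, read by resazurin assay (on this read-out lower numbers stand for stronger inhibition and higher numbers for weaker inhibition), which here measures harm to cells. In this test compound 1 gives 29.8 ug/mL. Compound 3 gives 46 ug/mL, and these two numbers lie within the usual scatter of each other, so they cannot be ranked. The entry for compound 2, > 90 ug/mL, is a limit of the assay and not a number.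

The next compound to be tested is compound 4 `N=C(N)c1ccc2[nH]c(-c3ccc4nc(-c5ccc6ccccc6c5)[nH]c4c3)nc2c1`. It keeps the core of compound 1 but carries naphthalen-2-yl in place of 3,4-difluorophenyl on an aromatic carbon. Within the data shown here, no two measured compounds differ in one place only, so the effect of a change like this has not been seen directly. With so little to go on, the safest expectation in this assay is no step beyond the scatter, in either direction, starting from compound 1 at 29.8 ug/mL. The expected change is a 1.0-fold higher number from compound 1 to compound 4 (0.00 log units; within the scatter). For compound 4 the estimated value is 30 ug/mL, with an expected range from 12 ug/mL to 70 ug/mL.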

Compound 4, half-maximal inhibitory concentration: 34.7 ug/mL
For compound 4 the middle estimate is 1.2-fold (0.06 log units) below the measured one; measured number inside the range.
By their numbers in this assay, from the lowest: compounds 1, 4 and 3 (each within the scatter of the next). At a limit, above all of these: compound 2.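

In this assay, among these compounds, this pair gives the first direct look at a single change on an aromatic carbon of a five-membered aromatic ring with 2 nitrogen, and the outcome is a 1.2-fold higher number from compound 1 to compound 4 (0.07 log units; within the scatter). On this read-out, 3,4-difluorophenyl and naphthalen-2-yl cannot be told apart, even though naphthalen-2-yl has 10 heavy atoms against 8, carries 2 six-membered aromatic rings instead of one, and has no fluorine, so at this position these differences in the group come with no step beyond the scatter. Nothing measured among these compounds offers an explanation for this result.

Both groups in this pair are made of aromatic rings, with 0 hydrogen-bond donors, 0 hydrogen-bond acceptors and no net charge, so they say little about how a group of a different kind would behave here. Going by these compounds, it remains open whether an amine, a carboxylic acid or a longer saturated carbon chain at the same position would stay within the scatter of compound 1 in this assay or move clearly away from it.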